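Notes on the amide-nitrogen substituent of the series

A few compounds are considered here, and "the series" means these few. Any claim that something is new, unique, unknown or untested is made for them only; others in the source may bear on it.

Measured so far:
compound 1, `CCOC(=O)/C=C1/C(=O)Nc2ccccc21`, in a functional assay on OVCAR-3 cells (Homo sapiens) for inhibition, read by CCK-8 assay, with a stated time of 72 h, tested at 20 uM (on this read-out lower numbers stand for less inhibition of growth and higher numbers for more inhibition of growth at the one concentration tested), gives 57.3%
compound 2, `CC(C)(C)OC(=O)/C=C1/C(=O)Nc2ccccc21`, in this assay gives 59.6%
compound 3, `CC(C)(C)OC(=O)/C=C1/C(=O)N(Cc2ccccc2)c2ccccc21`, in this assay gives 58.9%

The three numbers lie close together. The ester change, a number 2.3 percentage points higher from compound 1 to compound 2 (within the scatter), stays within the scatter, and so does the change at the ring nitrogen, a number 0.7 percentage points lower from compound 2 to compound 3 (within the scatter). Compound 3 and compound 1 show values that differ by an amount of the same order, so on the numbers shown compound 3 stands level with both neighbours.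

Compound 4, `CN1C(=O)/C(=C/C(=O)OC(C)(C)C)c2ccccc21`, differs from compound 3 by hydrogen in place of phenyl on a saturated chain carbon bound to an amide-type nitrogen in a ring. Among the compounds with values here, the one measured step that bears on this place is the benzyl-for-hydrogen step at the ring nitrogen, a number 0.7 percentage points lower from compound 2 to compound 3 (within the scatter), which brought no change beyond the scatter; the ester step at the other end of the molecule was equally flat. Cutting the benzyl back to methyl is therefore expected to leave this assay essentially where it is, with a step of about a number 0.9 percentage points lower from compound 3 to compound 4 (within the scatter), none beyond the scatter.

Compound 4 is thus estimated at 58%, within the range 48% to 68%.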

Compound 4, percent growth inhibition at one concentration: 57.1%
The estimate for compound 4 lay 0.9 percentage points above the measured number; the range from low to high includes it.
By their numbers in this assay, from the lowest: compounds 4, 1, 3 and 2 (each within the scatter of the next).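

The cut from benzyl to methyl gives a number 1.8 percentage points lower from compound 3 to compound 4 (within the scatter) in this assay and methyl in place of hydrogen gives a number 2.5 percentage points lower from compound 2 to compound 4 (within the scatter) on the amide-type nitrogen in a ring. With the tert-butyl ester held fixed, this nitrogen has now carried hydrogen, methyl and benzyl with no step beyond the scatter, and the phenyl on the saturated chain carbon can go without a change beyond the scatter, which the benzyl step alone could not show. No measured evidence bears on why the read-out stays level at this position.

Still open, from the compounds shown here alone, is whether a different group on this nitrogen, such as a longer chain ending in an amine or a carboxylic acid, would give a step beyond the scatter. Also open, going by these compounds, is whether the same level picture holds at concentrations other than the one tested.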